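The compounds below may be only part of what the source reports. "The series", "measured", "known", "first", "only" and "open" are said of these compounds alone.

Measured so far:

Compound 1, `Cc1ccccc1-n1nncc1CN1C(=O)C2(C(C#N)=C(N)Oc3c2c2nc4ccccc4nc2c2ccccc32)c2ccccc21`: in a functional assay on A549 cells (Homo sapiens) for antiproliferative activity, read by MTT assay, with a stated time of 48 h (a higher number here means a weaker inhibitor, a lower number a stronger inhibitor), compound 1 gives > 50000 nM.
Compound 2, `Cc1cccc(-n2nncc2CN2C(=O)C3(C(C#N)=C(N)Oc4c3c3nc5ccccc5nc3c3ccccc43)c3ccccc32)c1`: compound 2 gives 39600 nM.
Compound 3, `Cc1ccccc1-n1nncc1CN1C(=O)C2(C(C#N)=C(N)Oc3c(N)cc4nc5ccccc5nc4c32)c2ccccc21`: compound 3 gives 31700 nM.

The value of compound 1 is only a limit of the assay, (the limit of > 50000 nM in this assay, at which 1 of the 3 values shown sits). Compound 2 differs from compound 1 in one place, (3-methylphenyl in place of 2-methylphenyl on an aromatic nitrogen). The step that this change made is an at least 1.2-fold lower number from compound 1 to compound 2 (0.10 log units; that floor lies within the scatter); as compound 1 sits at a limit, only a floor for this step is known.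

Compound 3 carries a different core; the difference between the core of compound 1 and the core of compound 3 is not broken down here. Compound 4, `Cc1cccc(-n2nncc2CN2C(=O)C3(C(C#N)=C(N)Oc4c(N)cc5nc6ccccc6nc5c43)c3ccccc32)c1`, has not been measured yet. Within the data shown here, it differs from compound 3 by 3-methylphenyl in place of 2-methylphenyl on an aromatic nitrogen, the same change at the same place as the one from compound 1 to compound 2.

The expectation for compound 4 rests on the step of an at least 1.2-fold lower number from compound 1 to compound 2 (0.10 log units; that floor lies within the scatter), which gives no sign of a large shift. Compound 4 is therefore expected to show a 1.1-fold lower number from compound 3 to compound 4 (0.05 log units; within the scatter). The estimate for compound 4 is 28000 nM, expected to fall between 12000 nM and 60000 nM.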

Compound 4, half-maximal inhibitory concentration: 12300 nM
Estimate against measurement, compound 4: 2.3-fold (0.36 log units) above; low and high end bracket the measured number.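

In this assay, putting 3-methylphenyl in place of 2-methylphenyl on the aromatic nitrogen gives a 2.6-fold lower number from compound 3 to compound 4 (0.41 log units; beyond the scatter). This shows that the change has a measurable effect on the core of compound 3, and the same change on the core of compound 1 gives a result that can be set beside it: the same change on two cores in this assay, an at least 1.2-fold lower number (0.10 log units; that floor lies within the scatter) from compound 1 to compound 2 and a 2.6-fold lower number (0.41 log units; beyond the scatter) from compound 3 to compound 4; the limit leaves it open whether they differ. It does not show that the change has the same size on both cores, since the value of compound 1 is a limit and not a number: the limit of > 50000 nM in this assay, at which 1 of the 4 values shown sits.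

On these data alone, all four compounds carry a methylphenyl group on that nitrogen, so it remains open how a plain phenyl, a chlorophenyl or a methoxyphenyl group would behave there. As far as these compounds go, it also remains open whether the step seen here would hold on a third core or in another cell line.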